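The compounds below may be only part of what the source reports. "The series", "measured", "known", "first", "only" and "open" are said of these compounds alone.

Compound 1 `C=C1C(=O)[C@H]2C[C@]1(O)CC1=C2[C@]2(C)CCCC(C)(C)[C@H]2CC1` is the starting point of this small series, and in a functional assay on MDA-MB-231 cells (Homo sapiens) for cytotoxicity, read by MTT assay, with a stated time of 24 h (on this read-out lower numbers stand for stronger inhibition and higher numbers for weaker inhibition), compound 1 gives 3400 nM. Compound 2 `C=C1C(=O)[C@H]2C[C@]1(O)CC1=C2[C@]2(C)CCC[C@](C)(CO)[C@H]2CC1` differs from it by one change, (hydroxy in place of hydrogen on a saturated chain carbon bound to a saturated ring carbon), and in this assay compound 2 gives 10400 nM; this change produced a 3.1-fold higher number from compound 1 to compound 2 (0.49 log units; beyond the scatter). Compound 3 `C[C@@H]1C(=O)[C@H]2C[C@]1(O)CC1=C2[C@]2(C)CCCC(C)(C)[C@H]2CC1` carries a different core; how the core of compound 3 differs from the core of compound 1 is not broken down here. For compound 3 only a limit is reported in this assay, namely > 50000 nM. Compound 4 `C[C@@H]1C(=O)[C@H]2C[C@]1(O)CC1=C2[C@]2(C)CCC[C@@](C)(CO)[C@H]2CC1` has not yet been measured in this assay; it differs from compound 3 by hydroxy in place of hydrogen on a saturated chain carbon bound to a saturated ring carbon, the same change as that from compound 1 to compound 2. In compound 1 that change gave a modest rise in the number, and since compound 3 already sits at the limit, no number below that limit is expected for compound 4. Compound 4 is therefore estimated at about 120000 nM, with a likely span from 50000 nM to 400000 nM. The expected step is a step that the limit leaves unreadable from compound 3 to compound 4, and it rests on the reading for compound 3 being a limit because of the limit of > 50000 nM in this assay, at which 1 of the 3 values shown sits.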

Compound 4, half-maximal inhibitory concentration: > 50000 nM
Compound 4 ended at the assay's limit (the forecaster's own chance of this, stated with the estimate: 90%); the middle value does not contradict the limit.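

No step can be read from compound 3 to compound 4, since both values are limits and not numbers: the limit of > 50000 nM in this assay, at which 2 of the 4 values shown sit. The compounds shown leave open whether hydroxy in place of hydrogen on a saturated chain carbon bound to a saturated ring carbon changes the number at all on the core of compound 3.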